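A few compounds are considered here, and "the series" means these few. Any claim that something is new, unique, unknown or untested is made for them only; others in the source may bear on it.

Compound 1 `N#Cc1ccc(Nc2nccc(Oc3ccc4cc(C#N)ccc4c3Cl)n2)cc1` carries a chloro group on the shared core, and in an ADME assay on MT4 cells (Homo sapiens) for cytotoxicity, read by MTT assay, with a stated time of 4 days (a higher number here means that more compound is tolerated, a lower number that less compound is tolerated), compound 1 gives 269000 nM. Compound 2 `N#Cc1ccc(Nc2nccc(Oc3ccc4cc(C#N)ccc4c3)n2)cc1` has a hydrogen in that place. In this assay compound 2 reaches only a limit of the assay, > 68800 nM, and not a number. The step that the limit leaves unreadable from compound 1 to compound 2 therefore cannot be sized; its evidence is confined to the limit of > 68800 nM in this assay, at which 1 of the 2 values shown sits. Compound 2 thus stands at a limit, with no number of its own to set beside compound 1.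

Compound 3 `N#Cc1ccc(Nc2nccc(Oc3ccc4cc(C#N)ccc4c3Br)n2)cc1` is the next member. The change from compound 2 to compound 3 is bromo in place of hydrogen on an aromatic carbon. Among the measured compounds shown here, only one measured step bears on this change, a step that the limit leaves unreadable from compound 1 to compound 2, and its size is hidden by the limit. The expected step that the limit leaves unreadable from compound 2 to compound 3 is estimated to move toward greater tolerance, though from a limit its size cannot be confirmed. Compound 3 is therefore estimated at 250000 nM, with a range from 80000 nM to 600000 nM, because compound 1 with its chloro group in the same place gives 269000 nM.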

Compound 3, half-maximal cytotoxic concentration: 283000 nM
Compound 3: the middle estimate sits 1.1-fold (0.05 log units) below what was measured; low and high end bracket the measured number.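

In this assay, putting bromo where compound 1 has chloro on this aromatic carbon is a 1.1-fold higher number from compound 1 to compound 3 (0.02 log units; within the scatter), so the two groups cannot be told apart in this read-out. Among the compounds shown here, this is the first comparison at this position that gives a readable size, since both compounds have a real number rather than a limit, and it shows that exchanging one of these halogens for the other, which adds no ring, no charge and no hydrogen-bond donor or acceptor, leaves the tolerated concentration where it was within the usual scatter. The steps from the hydrogen compound to either halogen compound still cannot be read, so nothing can be said about whether a halogen at this position changes tolerance at all compared with hydrogen: the limit of > 68800 nM in this assay, at which 1 of the 3 values shown sits.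

Going by these compounds, what a smaller halogen such as fluoro, a methyl group or a methoxy group would give on this aromatic carbon remains open. So does the result with an amine or a carboxylic acid there, and whether compounds carrying such groups would fall in line with compound 1 and compound 3 or move away from them.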